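The compounds below may be only part of what the source reports. "The series", "measured", "known", "first", "only" and "open" are said of these compounds alone.

Measured compounds in an ADME assay on Akata cells (Homo sapiens) for cytotoxicity, with a stated time of 7 days; a higher number here means that more compound is tolerated, a lower number that less compound is tolerated:
compound 1 `CCCCSc1nc(N)nc2c1ncn2/C=C1/CC1(CO)CO` gives > 20000 nM, a limit of the assay
compound 2 `Nc1nc(NC2CC2)c2ncn(/C=C3/CC3(CO)CO)c2n1` gives > 20000 nM, a limit of the assay
compound 3 `CCCNc1nc(N)nc2c1ncn2/C=C1/CC1(CO)CO` gives > 24000 nM, a limit of the assay

Compound 2 stands at a limit, and the two other values are limits as well. None of the three is a number, so no order among the compounds can be read. The steps a step that the two limits leave unreadable from compound 1 to compound 2, a step that the two limits leave unreadable from compound 1 to compound 3 and a step that the two limits leave unreadable from compound 2 to compound 3 are accordingly of unreadable size. Both limits recur in the set: the limit of > 20000 nM in this assay, at which 2 of the 3 values shown sit, and (the limit of > 24000 nM in this assay, at which 1 of the 3 values shown sits).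

Compound 4 `Nc1nc(N2CCCC2)c2ncn(/C=C3/CC3(CO)CO)c2n1` differs from compound 2 by pyrrolidin-1-yl in place of cyclopropylamino on an aromatic carbon. Among the measured compounds shown here, no measured step bears on this change in a readable way; the three unreadable steps give neither a size nor a direction to expect in this assay, and what they show is only that every measured compound sits at a limit. The expectation for compound 4 is that it too sits at a limit, with the step of a number no higher from compound 2 to compound 4 (the limit leaves the size open) expected to stay within the scatter. The estimate for compound 4 is 20000 nM, between 10000 nM and 60000 nM.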

Compound 4, half-maximal cytotoxic concentration: > 24000 nM
Compound 4 ended at the assay's limit; the forecaster's own chance of this, stated with the estimate: 80%; middle value at least 1.2-fold (0.07 log units) away from the limit.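

In this assay compound 4 gives > 24000 nM, a limit of the assay. Its steps from compounds 1, 2 and 3 therefore cannot be read: the limit of > 24000 nM in this assay, at which 2 of the 4 values shown sit.

As far as these compounds go, the concentration at which any of compounds 1, 2, 3 and 4 turns cytotoxic stays open, and with it any order among them.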